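Swapping a pentyl chain for a cyclohexyl ring

The source may report more compounds than this note shows. Statements on the series, on what has been measured and on what is new or still open speak of the compounds shown alone.

Measured compounds:
- Compound 1, `CC(C)COc1nc(C(C)(C)C)ccc1CNC(=O)C(C)c1ccc(NS(C)(=O)=O)c(F)c1`: 0.6 nM
- Compound 2, `CCCCCc1nc(C(C)(C)C)ccc1CNC(=O)C(C)c1ccc(NS(C)(=O)=O)c(F)c1`: 1.9 nM

Both compounds were tested in an assay on cells for antagonist activity at transient receptor potential cation channel subfamily V member 1 (Homo sapiens), read by FLIPR and calcium flux, with a stated time of 6 min; on this read-out lower numbers stand for stronger inhibition and higher numbers for weaker inhibition. Compound 1, with its isobutoxy group, gives 0.6 nM, and compound 2, with a pentyl chain in that position, gives 1.9 nM. Among the compounds with values here, the only measured step, a 3.2-fold higher number from compound 1 to compound 2 (0.50 log units; beyond the scatter), shows that replacing isobutoxy by pentyl weakens binding. Among the two numbers available, compound 2 therefore stands at the higher, weaker end, with compound 1 as its only neighbour.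

Compound 3, `CC(C(=O)NCc1ccc(C(C)(C)C)nc1C1CCCCC1)c1ccc(NS(C)(=O)=O)c(F)c1`, has not yet been measured. It differs from compound 2 in a single place: cyclohexyl in place of pentyl on an aromatic carbon. Within the data shown here, no measured step shows a pentyl chain becoming a cyclohexyl ring, so the one known step only indicates how sensitive this position is to change. Since pentyl and cyclohexyl are both plain hydrocarbon groups of comparable bulk, compound 3 is expected to land close to compound 2, with a 1.3-fold lower number from compound 2 to compound 3 (0.10 log units; within the scatter) as the expected shift. The estimate for compound 3 in this assay is 1.5 nM, with a plausible range from 0.5 nM to 5 nM.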

Compound 3, inhibition constant: 3.1 nM
Compound 3: the middle estimate sits 2.1-fold (0.32 log units) below what was measured; the range from low to high includes it.
By their numbers in this assay, from the lowest: compound 1; then compounds 2 and 3 (each within the scatter of the next).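

In this assay, a 1.6-fold higher number from compound 2 to compound 3 (0.21 log units; within the scatter), so at this position on the aromatic ring, which is next to the ring nitrogen, the data do not separate the open pentyl chain from the cyclohexyl ring, even though one group is flexible-looking on paper and the other is a closed ring of six carbons. Within the data shown here, the comparison with the isobutoxy compound adds a second reading: a 5.2-fold higher number from compound 1 to compound 3 (0.71 log units; beyond the scatter), and with a 3.2-fold higher number from compound 1 to compound 2 (0.50 log units; beyond the scatter) this means that both groups made only of carbon give higher numbers than isobutoxy, the one group of the three that carries an oxygen, by steps beyond the scatter. Nothing among the data available explains why these numbers fall as they do.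

The compounds shown leave open whether the advantage of compound 1 goes with the oxygen itself or with the branched shape of its chain, since isobutoxy differs from the other two groups in both respects. A cyclohexyloxy group, which joins the same six-carbon ring to the core through an oxygen, or a piperidine ring, attached through its nitrogen, would bear directly on that question.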